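A Side-Chain Swap Starting From an Assay Limit

The source may report more compounds than this note shows. Statements on the series, on what has been measured and on what is new or still open speak of the compounds shown alone.

- Compound 1 `CN(C)CCCn1c(N)c(-c2nc3ccccc3s2)c2nc(C#N)c(C#N)nc21`: 1800 nM
- Compound 2 `CCN(CC)CCn1c(N)c(-c2nc3ccccc3n2C)c2nc(C#N)c(C#N)nc21`: > 50000 nM (a limit, not a number)
- Compound 3 `CN(C)CCCn1c(N)c(-c2nc3ccccc3n2C)c2nc(C#N)c(C#N)nc21`: not yet measured

In a functional assay on K562 cells (Homo sapiens) for antiproliferative activity, read by MTT assay, with a stated time of 48 h (on this read-out lower numbers stand for stronger inhibition and higher numbers for weaker inhibition), compound 1 gives 1800 nM. Compound 2 stands at > 50000 nM, which is a limit of the assay and not a number.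

Compound 3 differs from compound 2 in one place: (dimethylamino)methyl in place of diethylamino on a saturated chain carbon, two bonds along the chain from an aromatic nitrogen. Read one bond further out, 2-(diethylamino)ethyl gives way to 3-(dimethylamino)propyl. For the measured compounds named here, no measured pair shows what this change does in this assay, so any expectation is loose. Compound 1 gives a true number at 1800 nM, so a measurable value for compound 3 is expected. Compound 3 could still remain at the limit of the assay. A step of an at least 5.5-fold lower number from compound 2 to compound 3 (0.74 log units; beyond the scatter) is expected, in the direction of stronger inhibition. For compound 3 the estimated value is 9000 nM, with an expected range of 1800 nM to 45000 nM.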

Compound 3, half-maximal inhibitory concentration: 3560 nM
Compound 3: middle estimate off by 2.5-fold (0.40 log units), on the high side, within the range that was stated.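

In this assay, replacing 2-(diethylamino)ethyl with 3-(dimethylamino)propyl gives an at least 14-fold lower number from compound 2 to compound 3 (1.14 log units; beyond the scatter), so this side chain has a large effect on the read-out in the 1-methyl-1H-benzimidazol-2-yl series. The size of that step is only a lower bound, because the value of compound 2 is a limit and not a number: the limit of > 50000 nM in this assay, at which 1 of the 3 values shown sits.

With the 3-(dimethylamino)propyl chain held the same, 1-methyl-1H-benzimidazol-2-yl in place of 1,3-benzothiazol-2-yl on an aromatic carbon gives a 2.0-fold higher number from compound 1 to compound 3 (0.30 log units; within the scatter), which means the two groups cannot be told apart in this assay.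

The change alters both the chain length and the groups on the amine nitrogen, so the compounds shown leave open which of the two matters. A 2-(dimethylamino)ethyl or a 3-(diethylamino)propyl chain on the same core could separate them.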